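The source may hold more compounds than are shown below. What is called first, only, known or untested is meant among the compounds shown, and "the series" means these compounds.

Working notes on the series.

Of the compounds shown here, three carry numbers so far. Compound 1 `O=C(O)CCc1ccc(OCc2ncc(-c3cccc(F)c3)o2)cc1` in a functional assay on CHO cells for agonist activity at Free fatty acid receptor 1 (Homo sapiens), read by FLIPR and calcium flux, in the presence of a further agent that is not named here (a lower number here means that less compound is needed, a higher number that more compound is needed for the effect), gives 1070 nM. Compound 2 `CC(Oc1ccc(CCC(=O)O)cc1)c1nc(-c2ccccc2)no1` in this assay gives 2390 nM. Compound 3 `O=C(O)CCc1ccc(OCc2nc(-c3ccc(F)cc3)no2)cc1` in this assay gives 680 nM, the lowest of the three numbers; against compound 1 the gap stays within the scatter, so no order between compound 3 and compound 1 is claimed, while against compound 2 the gap lies beyond the scatter. Among the measured compounds shown here, no pair among the measured compounds differs in only one place, so no single-point step is available for reading the effect of the aryl group.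

Compound 4 `COc1cccc(-c2noc(COc3ccc(CCC(=O)O)cc3)n2)c1` is the next compound to be measured in this assay. Its difference from compound 3 is 3-methoxyphenyl in place of 4-fluorophenyl on an aromatic carbon. With nothing in the measured set that isolates this kind of exchange, the expectation rests on compound 3 alone, and the step from compound 3 to compound 4 is expected to be small, not beyond the scatter in either direction, with the estimated step being a 1.2-fold higher number from compound 3 to compound 4 (0.07 log units; within the scatter). Compound 4 is therefore estimated at 800 nM in this assay, with a range from 300 nM to 2500 nM.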

Compound 4, half-maximal effective concentration: 2670 nM
Beside the measured number, compound 4's estimate is 3.3-fold (0.52 log units) below it, and the stated range ends below it.
By their numbers in this assay, from the lowest: compounds 3 and 1 (each within the scatter of the next); then compounds 2 and 4 (each within the scatter of the next).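

The exchange of 4-fluorophenyl for 3-methoxyphenyl gives the series its first step that differs in one place: on the aromatic carbon between two ring nitrogen atoms, the step in this assay is a 3.9-fold higher number from compound 3 to compound 4 (0.59 log units; beyond the scatter). The number at this position therefore responds to the aryl group it carries, which compounds 1 and 2 could not show, as each differs from compound 3 in more than one place. The exchange changes both the substituent and its location on the phenyl ring, and the entering group adds a hydrogen-bond acceptor, but no measurement available here bears on what lies behind the step.

The compounds shown leave open whether the step follows the methoxy group or the ring location, a question that 4-methoxyphenyl or 3-fluorophenyl on this same carbon of the shared core would separate. They also leave open how far the step carries to other groups at this position, such as an amine or a nitrile on the phenyl ring, and whether it holds on the cores of compound 1 and compound 2.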